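Ester aryl exchange on two related cores

The compounds below may be only part of what the source reports. "The series", "measured", "known", "first", "only" and "open" are said of these compounds alone.

Compound 1 `CC1=CC[C@H]2[C@H](CC[C@]2(C)O)C(C)(C)[C@@H]1CC[C@H]1[C@]2(C)CC[C@H](OC(=O)c3ccccc3)C(C)(C)O[C@H]2CC[C@@]1(C)O` and compound 2 `CC1=CC[C@H]2[C@H](CC[C@]2(C)O)C(C)(C)[C@@H]1CC[C@H]1[C@]2(C)CC[C@H](OC(=O)c3ccncc3)C(C)(C)O[C@H]2CC[C@@]1(C)O` share one core. In a functional assay on MDA-MB-231 cells (Homo sapiens) for antiproliferative activity, read by MTT assay, with a stated time of 72 h (on this read-out higher numbers stand for weaker inhibition and lower numbers for stronger inhibition), compound 1 gives 16100 nM, and compound 2 gives 18000 nM. The two differ by pyridin-4-yl in place of phenyl on a carbonyl carbon, a change that produced a 1.1-fold higher number from compound 1 to compound 2 (0.05 log units; within the scatter). Compound 3 `CC1=CC[C@H]2[C@@H]1CC=C(C)[C@@H](CC[C@H]1[C@]3(C)CC[C@H](OC(=O)c4ccccc4)C(C)(C)O[C@H]3CC[C@@]1(C)O)C2(C)C` is built on a different core; how this core differs from that of compound 1 is not broken down here. In this assay compound 3 gives 18400 nM, a number within the scatter of both compound 1 and compound 2. Compound 4 `CC1=CC[C@H]2[C@@H]1CC=C(C)[C@@H](CC[C@H]1[C@]3(C)CC[C@H](OC(=O)c4ccncc4)C(C)(C)O[C@H]3CC[C@@]1(C)O)C2(C)C` stands to compound 3 as compound 2 stands to compound 1, through the same change, (pyridin-4-yl in place of phenyl on a carbonyl carbon), at the same place. Because the same change earlier gave a 1.1-fold higher number from compound 1 to compound 2 (0.05 log units; within the scatter), the step expected for compound 4 is a 1.1-fold higher number from compound 3 to compound 4 (0.04 log units; within the scatter). In this assay compound 4 is estimated at 20000 nM, expected to fall between 10000 nM and 40000 nM.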

Compound 4, half-maximal inhibitory concentration: 19100 nM
For compound 4 the middle estimate is 1.0-fold (0.02 log units) above the measured one; the measured number falls inside the stated range.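

On the core of compound 3, pyridin-4-yl in place of phenyl on a carbonyl carbon gave a 1.0-fold higher number from compound 3 to compound 4 (0.02 log units; within the scatter) in this assay. Set beside the step on the core of compound 1, the change reads the same on both cores: the same change on two cores in this assay, a 1.1-fold higher number (0.05 log units; within the scatter) from compound 1 to compound 2 and a 1.0-fold higher number (0.02 log units; within the scatter) from compound 3 to compound 4, 1.1-fold (0.03 log units) apart, within the scatter of two such steps. This shows that the exchange stayed within the scatter on these two cores, but it does not show that a step beyond the scatter would carry over from one core to the other, nor does it say anything about other cores.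

The compounds shown leave open whether a longer alkyl chain or an aminophenyl group in place of phenyl on a carbonyl carbon would give a step beyond the scatter on either core. They also leave open whether both cores would then respond alike.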